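Two Measured Compounds and an Ethyl Swap at Ring Nitrogen

A few compounds are considered here, and "the series" means these few. Any claim that something is new, unique, unknown or untested is made for them only; others in the source may bear on it.

Measured so far:
- compound 1, `CC(C)n1nc(-c2ccnc3[nH]c(C4CCN(CC(=O)N(C)C)CC4)cc23)ccc1=O`: 3.1 uL/min
- compound 2, `CN(C)C(=O)CN1CCC(c2cc3c(-c4ccc(=O)n(C5CCOCC5)c4)ccnc3[nH]2)CC1`: 2.3 uL/min

Two compounds sharing a common core have been studied in an ADME assay on cells (Hepatocyte, Rattus norvegicus) for metabolic stability; a higher number here means faster removal of the compound, a lower number slower removal. Compound 1 gives 3.1 uL/min in this assay, and compound 2 gives 2.3 uL/min. Of the two numbers, compound 2 has the lower one, but the gap to compound 1 falls within the usual scatter of this assay, so the two readings are not distinguishable from each other.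

Compound 3, `CCn1cc(-c2ccnc3[nH]c(C4CCN(CC(=O)N(C)C)CC4)cc23)ccc1=O`, has not yet been measured in this assay. It differs from compound 2 in one place: ethyl in place of oxan-4-yl on an aromatic nitrogen. The change sits on an aromatic nitrogen of a six-membered aromatic ring with one nitrogen, ortho to a group of one heavy atom and meta to a large group.

For the measured compounds named here, since no step between measured compounds is available, the expectation for compound 3 rests on the two values at hand. Both lie close together, so the step from compound 2 to compound 3 is expected to be small, at most a modest rise that stays within the scatter, a 1.3-fold higher number from compound 2 to compound 3 (0.10 log units; within the scatter) being the estimated change. Compound 3 is therefore expected to give about 2.9 uL/min in this assay, with a range from 1.3 uL/min to 6.5 uL/min.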

Compound 3, intrinsic clearance in a liver preparation (reported as CLH), per the amount of preparation that the assay uses: < 1 uL/min
Compound 3 ended at the assay's limit; the forecaster's own chance of this, stated with the estimate: 10%; middle value at least 2.9-fold (0.46 log units) away from the limit.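

Ethyl in place of oxan-4-yl on an aromatic nitrogen gives an at least 2.3-fold lower number from compound 2 to compound 3 (0.36 log units; beyond the scatter), so in this assay the group at this position can move the read-out, something the close readings of compound 1 and compound 2 had not revealed. The second comparison points the same way: a group of 9 heavy atoms with one six-membered aromatic ring with 1 hetero atom, in place of a group of 10 heavy atoms with one six-membered aromatic ring with 2 hetero atoms, gives an at least 3.1-fold lower number from compound 1 to compound 3 (0.49 log units; beyond the scatter), although that change alters the ring as well as its substituent on nitrogen. Compound 3 reads < 1 uL/min, which is a limit of the assay and not a number, and both steps give only a minimum size because of where this value sits: the limit of < 1 uL/min in this assay, at which 1 of the 3 values shown sits.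

From the compounds shown here alone, how far the true value of compound 3 lies past that limit remains open. It is also unknown whether the fall tracks the loss of the oxan-4-yl ring or is particular to ethyl, a question that a methyl, a longer chain or a cyclopropyl on the same nitrogen would address.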